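The source may hold more compounds than are shown below. What is called first, only, known or untested is meant among the compounds shown, and "the series" means these compounds.

Compound 1 `CC(=O)Nc1cc(-c2c(Nc3cc[nH]n3)nc3cccnn23)nc(C)n1` — 6.3 L/kg
Compound 2 `Cc1nc(Nc2cccnc2)cc(-c2c(Nc3cc[nH]n3)nc3cccnn23)n1` — "not determined" (no result reported)

Two compounds of the same core were tested in an in vivo ADME assay on the whole organism for pharmacokinetics, with Rattus norvegicus as the target, at a dose of 0.5 mg/kg by the intravenous route; on this read-out lower numbers stand for narrower distribution and higher numbers for wider distribution into tissues. Compound 1 gives 6.3 L/kg in this assay, a wide distribution into tissues. Compound 2 returned no number in this assay, so it stands nowhere on the scale and cannot be ranked against compound 1.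

Compound 3 `CNc1cc(-c2c(Nc3cc[nH]n3)nc3cccnn23)nc(C)n1` is the next compound, and it differs from compound 2 in one place: methyl in place of pyridin-3-yl on a nitrogen on an aromatic ring. Without a value for compound 2, the step to compound 3 cannot be measured against anything, and the expectation is that the change is no larger than the usual scatter in this assay, in no firm direction. Taking compound 1 as the only measured point with the same core, compound 3 is expected to give about 4 L/kg in this assay, within a range from 1.5 L/kg to 11 L/kg.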

Compound 3, volume of distribution at steady state: 1.3 L/kg
Compound 3: middle estimate off by 3.1-fold (0.49 log units), on the high side; the whole stated range lies above it.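

In this assay the group on this nitrogen matters: methyl in place of acetyl gives a 4.8-fold lower number from compound 1 to compound 3 (0.69 log units; beyond the scatter) with the rest of the molecule unchanged. The step from compound 2 to compound 3 cannot be read, so pyridin-3-yl has no place on this scale and only the acetyl and methyl groups can be compared. Nothing in the data available explains why the number falls with this change.

The result rests on a single pair of compounds, so it does not show whether the drop follows the loss of the carbonyl or is specific to methyl. From the compounds shown here alone, how a longer chain such as propyl, or an unsubstituted amine on this nitrogen, would compare with compound 1 and compound 3 remains open.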